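Adding a Methoxy Group: What to Expect for Compound 4

This account rests on a few compounds, and the source may have more. Where it says the series, first, only, none or still open, it means among the compounds named here.

Compound 1 `Fc1ccc(/C=C/c2cc3ccccc3nc2Cl)cc1`: 38500 nM
Compound 2 `COc1ccc2nc(Cl)c(/C=C/c3ccc(F)cc3)cc2c1`: 9740 nM
Compound 3 `FC(F)(F)c1ccc(/C=C\c2cc3ccccc3nc2Cl)c(C(F)(F)F)c1`: "not determined" (no result reported)

In an ADME assay on 184B5 cells (Homo sapiens) for antiproliferative activity, read by sulforhodamine B assay, with a stated time of 72 h (on this read-out higher numbers stand for weaker inhibition and lower numbers for stronger inhibition), compound 1 gives 38500 nM and compound 2 gives 9740 nM. Within the data shown here, the single change between them, (methoxy in place of hydrogen on an aromatic carbon), produced a 4.0-fold lower number from compound 1 to compound 2 (0.60 log units; beyond the scatter). In this assay compound 3 gives "not determined" (no result reported), so no single number stands for it. Compound 4 `COc1ccc2nc(Cl)c(/C=C\c3ccc(C(F)(F)F)cc3C(F)(F)F)cc2c1` is built from compound 3 by the same kind of change, (methoxy in place of hydrogen on an aromatic carbon), with the place described in the same words. The difference between the two cores of compound 1 and compound 3 is not broken down here. The expected step is of similar size to a 4.0-fold lower number from compound 1 to compound 2 (0.60 log units; beyond the scatter). This rests on that one earlier pair only, and no starting number for compound 3 exists. Compound 4 is expected to give about 12000 nM in this assay, estimated between 2500 nM and 60000 nM.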

Compound 4, half-maximal inhibitory concentration: > 50000 nM
Compound 4 ended at the assay's limit (the forecaster's own chance of this, stated with the estimate: 25%); middle value at least 4.1-fold (0.61 log units) from the limit.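

No step can be read from compound 3 to compound 4, for which neither has a single number: compound 4 gives > 50000 nM, which is a limit of the assay. As far as these compounds go, what methoxy in place of hydrogen does to the core of compound 3 in this assay stays open.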